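Swapping the Ring Tail of an EP3 Ligand

This account rests on a few compounds, and the source may have more. Where it says the series, first, only, none or still open, it means among the compounds named here.

Measured so far in this assay:
compound 1 `CC(C)C(CC1C(=O)NC(=O)N1C)c1ccc(-c2ccc3cccc(F)c3c2)[nH]c1=O`: 17 nM
compound 2 `CCC(CC)C(/C=C1\OC(=O)NC1=O)c1ccc(-c2ccc3cccc(F)c3c2)[nH]c1=O`: 13 nM
compound 3 `O=C1NC(=O)/C(=C/C(c2ccc(-c3ccc4cccc(F)c4c3)[nH]c2=O)C2CCCCC2)O1`: 4 nM

In an assay on membranes from Chem-1 cells for displacement of a labelled ligand from prostaglandin E2 receptor EP3 subtype (Homo sapiens), read by scintillation counting, with a stated time of 2 h (a higher number here means a weaker inhibitor, a lower number a stronger inhibitor), compound 1 gives the highest of the three numbers, with compound 2 within the scatter of it and compound 3 beyond it. Compound 4 `C/C(=C1/OC(=O)NC1=O)C(c1ccc(-c2ccc3cccc(F)c3c2)[nH]c1=O)C(C)C` differs from compound 1 by a group of 9 heavy atoms (5 carbon, 1 nitrogen, 3 oxygen; one five-membered non-aromatic ring with 2 hetero atoms) in place of a group of 9 heavy atoms (5 carbon, 2 nitrogen, 2 oxygen; one five-membered non-aromatic ring with 2 hetero atoms), on a saturated chain carbon bound to an aromatic carbon and a saturated chain carbon. Among the measured compounds shown here, the only measured step, a 3.3-fold lower number from compound 2 to compound 3 (0.51 log units; beyond the scatter), alters the alkyl group rather than this ring tail, so it does not bear directly on the change. Compound 2 carries the same kind of ring tail that enters compound 4, and it shows a number within the scatter of compound 1, though it also differs elsewhere. The expected step is therefore small, a 1.4-fold lower number from compound 1 to compound 4 (0.15 log units; within the scatter), slightly toward a lower number. Compound 4 is estimated at 12 nM, in a range from 4 nM to 35 nM.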

Compound 4, inhibition constant: 17 nM
The estimate for compound 4 lay 1.4-fold (0.15 log units) below the measured number; low and high end bracket the measured number.
By their numbers in this assay, from the lowest: compound 3; then compounds 2, 1 and 4 (each within the scatter of the next).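

In this assay, putting the new ring tail in place of the (3-methyl-2,5-dioxoimidazolidin-4-yl)methyl group gives no change at the digits printed from compound 1 to compound 4 (within the scatter). Among the compounds shown here, this is the first comparison of two ring tails with the rest of the molecule unchanged, and at this saturated chain carbon the two are interchangeable within the scatter. No measurement here explains this match.

Going by these compounds, whether a carboxylic acid or an amine at this position would give a similar number remains open. So does the effect of a cyclohexyl group alongside the ring tail of compound 4.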